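The source may report more compounds than this note shows. Statements on the series, on what has been measured and on what is new or still open speak of the compounds shown alone.

Measured in an ADME assay on MDBK cells (Bos taurus) for cytotoxicity, read by MTT assay, with a stated time of 96 h; a higher number here means that more compound is tolerated, a lower number that less compound is tolerated:
- compound 1 `O=[N+]([O-])c1ccc(-c2nc3cc(C(F)(F)F)ccc3[nH]2)cc1`: 6000 nM
- compound 2 `Cn1c(-c2ccc([N+](=O)[O-])cc2)nc2cc(C(F)(F)F)ccc21`: > 100000 nM (a limit)
- compound 3 `O=[N+]([O-])c1ccc(-c2nc3cc(C(F)(F)F)ccc3n2C2CCCCC2)cc1`: 68000 nM

Compound 2 has only a limit, > 100000 nM, and no number.

The change to compound 4 `Cn1c(-c2ccc(N)cc2)nc2cc(C(F)(F)F)ccc21` is amino in place of nitro on an aromatic carbon.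

The measured steps, an at least 16-fold higher number from compound 1 to compound 2 (1.22 log units; beyond the scatter) and an 11-fold higher number from compound 1 to compound 3 (1.05 log units; beyond the scatter), are large, and an at least 1.4-fold lower number from compound 2 to compound 3 (0.16 log units; that floor lies within the scatter) has a floor within the scatter. All three change the group on an aromatic nitrogen, so none measures this change directly.

A modest fall in this assay is expected, with compound 3 at 68000 nM as the nearest number on a nitro compound with a substituted nitrogen.

The expected change is an at least 1.4-fold lower number from compound 2 to compound 4 (0.15 log units; that floor lies within the scatter).

For compound 4 the estimate is 70000 nM, with an expected range of 20000 nM to 100000 nM.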

Compound 4, half-maximal cytotoxic concentration: 74000 nM
Beside the measured number, compound 4's estimate is 1.1-fold (0.02 log units) below it; measured number inside the range.
By their numbers in this assay, from the lowest: compound 1; then compounds 3 and 4 (each within the scatter of the next). At a limit, above all of these: compound 2.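

Within the data shown here, this is the first step made on the aromatic carbon, para to a large group, rather than on the aromatic nitrogen, and in this assay it reads as an at least 1.3-fold lower number from compound 2 to compound 4 (0.13 log units; that floor lies within the scatter). With methyl on the aromatic nitrogen, compound 4 gives a measured number, 74000 nM. The step has only a floor, because compound 2 carries a limit and no number: the limit of > 100000 nM in this assay, at which 1 of the 4 values shown sits.

Going by these compounds, whether amino in place of nitro behaves the same with hydrogen or cyclohexyl on the aromatic nitrogen remains open. So does the outcome for an acetamide or a carboxylic acid on this carbon.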